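Cyclohexyl for isobutyl on the carbonyl: expected cytotoxicity

A few compounds are considered here, and "the series" means these few. Any claim that something is new, unique, unknown or untested is made for them only; others in the source may bear on it.

Compound 1, `NCCNc1cc(N2CCN(c3ccccc3)CC2)nc2ccccc12`, gives 20800 nM in an ADME assay on HEp-2 cells (Homo sapiens) for cytotoxicity, read by CCK-8 assay, with a stated time of 6 days; a lower number here means that less compound is tolerated, a higher number that more compound is tolerated.
Compound 2, `CC(C)CC(=O)N1CCN(c2cc(NCCN)c3ccccc3n2)CC1`, gives > 100000 nM in this assay, which is a limit of the assay and not a number.
Compound 3, `NCC(O)CNc1cc(N2CCC(c3ccccc3)CC2)nc2ccccc12`, gives 20800 nM in this assay.

Among the three values shown, compound 2 is the one that sits at the limit of > 100000 nM in this assay, at which 1 of the 3 values shown sits, while compounds 1 and 3 give plain numbers. Within the data shown here, compound 2 is thus the best-tolerated compound measured so far, as far as the assay can tell.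

Compound 4, `NCCNc1cc(N2CCN(C(=O)C3CCCCC3)CC2)nc2ccccc12`, differs from compound 2 by cyclohexyl in place of isobutyl on a carbonyl carbon. Among the measured compounds shown here, only one measured step touches this part of the molecule: an at least 4.8-fold higher number from compound 1 to compound 2 (0.68 log units; beyond the scatter), which moved the value from a number up to the limit. Compound 4 keeps the carbonyl that compound 2 gained in that step and changes only the carbon group attached to it. For the measured compounds named here, no measured pair shows what a swap of isobutyl for cyclohexyl does here.

Compound 4 is therefore expected to stay close to compound 2, with a step of a number no higher from compound 2 to compound 4 (the limit leaves the size open). The estimate for compound 4 is 100000 nM, expected to lie between 30000 nM and 200000 nM, with a good chance that the assay again reports only a limit.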

Compound 4, half-maximal cytotoxic concentration: > 100000 nM
Compound 4: only a limit was reported; the forecaster's own chance of this, stated with the estimate: 55%; the middle value sits exactly at the limit.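

Putting cyclohexylcarbonyl in place of phenyl on the amine nitrogen in the ring gives an at least 4.8-fold higher number from compound 1 to compound 4 (0.68 log units; beyond the scatter), so the rise first seen with isobutylcarbonyl is not confined to that one group. Compound 4 gives > 100000 nM in this assay, which is a limit of the assay and not a number, and it shows that a carbonyl carrying a six-membered carbon ring can be tolerated as well as far as this read-out can tell, just as one carrying an open chain can. The step between compound 2 and compound 4 cannot be read, so the position shows no order between isobutyl and cyclohexyl, and the assay cannot separate them: the limit of > 100000 nM in this assay, at which 2 of the 4 values shown sit.

The compounds shown leave open how much compound the cells tolerate beyond the limit, and whether any group on this carbonyl would bring the value back down to a plain number. A carbonyl carrying a phenyl ring, an amine or a longer chain would test whether the tolerance holds across other kinds of group, or only for the two carbon groups seen here.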